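Swapping the Acid Chain for a Hydrazide Ether

The compounds below may be only part of what the source reports. "The series", "measured", "known", "first", "only" and "open" are said of these compounds alone.

Compound 1 `O=C(O)CCc1ccncc1-c1ccc2ccccc2c1` gives 101% in an assay on a protein complex for inhibition of CDK8/Cyclin C (Homo sapiens), with a stated time of 1 h, tested at 10 uM; on this read-out lower numbers stand for less inhibition and higher numbers for more inhibition at the one concentration tested (going by the name of the read-out).
Compound 2 `O=C(CCc1ccncc1-c1ccc2ccccc2c1)N1CCOCC1` gives 100% in this assay.
Compound 3 `O=C(/C=C/c1ccncc1-c1ccc2cccnc2c1)N1CCOCC1` gives 33% in this assay.

Among these three, compound 1 stands highest, with compound 2 close behind within the scatter and compound 3 far lower. Within the data shown here, the one measured step of a single change, a number 1 percentage points lower from compound 1 to compound 2 (within the scatter), shows that replacing the hydroxy of the acid with morpholin-4-yl leaves the read-out unchanged. Compound 3 differs from compound 1 in more than one place, so its low value cannot be tied to any single change.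

Compound 4 `NNC(=O)COc1ccncc1-c1ccc2ccccc2c1` carries (aminocarbamoyl)methoxy in place of 2-carboxyethyl on an aromatic carbon. Here the whole 2-carboxyethyl chain is exchanged, not only its terminal group, so the step from compound 1 to compound 2 bears on it only loosely: it shows that the number stays level when the end of the chain is changed, but says nothing about the attachment through oxygen. A modest fall is therefore expected, a number 21 percentage points lower from compound 1 to compound 4 (beyond the scatter), and compound 4 is estimated at 80%, within 50% to 100%.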

Compound 4, a percentage reported as inhibition, at one concentration (the size of the read-out at that concentration, not a potency): 19%
Beside the measured number, compound 4's estimate is 61 percentage points above it, and the stated range ends above it.
By their numbers in this assay, from the lowest: compound 4; then compound 3; then compounds 2 and 1 (each within the scatter of the next).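

In this assay the exchange of 2-carboxyethyl for (aminocarbamoyl)methoxy on the aromatic carbon opposite the ring nitrogen gives a number 82 percentage points lower from compound 1 to compound 4 (beyond the scatter) and so shows that this position is not indifferent to what it carries. The earlier step, a number 1 percentage points lower from compound 1 to compound 2 (within the scatter) on the same chain, had shown only that the end of the chain could change with the number staying level; replacing the chain as a whole and attaching it through oxygen takes most of the read-out away. No measurement shown here bears on why the number falls.

Compound 4 changes the attachment and the chain end at once, so the compounds shown do not say which of the two carries the fall. From the compounds shown here alone, a carboxymethoxy chain, or a hydrazide on an all-carbon chain, would separate them, and whether a simple amine at this position keeps the number also remains open.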